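The source may hold more compounds than are shown below. What is called first, only, known or untested is meant among the compounds shown, and "the series" means these compounds.

Compound 1 `Cc1cc(NC(=O)Nc2ccc(O)cc2)c2ccccc2n1`, compound 2 `CSc1ccc(NC(=O)Nc2cc(C)nc3ccccc23)cc1` and compound 3 `COc1ccccc1NC(=O)Nc1cc(C)nc2ccccc12` share one core and differ only in the aryl urea part. In an ADME assay on Raji cells (Homo sapiens) for cytotoxicity, with a stated time of 72 h (on this read-out higher numbers stand for an effect only at larger amounts of compound and lower numbers for an effect already at smaller amounts), compound 1 gives only a limit, > 25000 nM. In this assay compound 2 likewise gives only a limit, > 25000 nM. In this assay compound 3 also gives only a limit, > 25000 nM. The change from compound 2 to compound 4 `Cc1cc(NC(=O)Nc2ccc(C(F)(F)F)cc2)c2ccccc2n1` is trifluoromethyl in place of methylsulfanyl on an aromatic carbon. Within the data shown here, the one measured step that bears on it, a step that the two limits leave unreadable from compound 1 to compound 2, is not readable, and the limit of > 25000 nM in this assay, at which 3 of the 3 values shown sit, leaves no readable step in this assay at all. Compound 2 stands at that limit, so no step beyond the scatter can be expected. Compound 4 is therefore expected to sit at the same limit, with an estimate of 30000 nM, between 10000 nM and 100000 nM. The step that the limit leaves unreadable from compound 2 to compound 4 that this estimate means is expected to be none beyond the scatter.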

Compound 4, half-maximal effective concentration: 23000 nM
Compound 4: the middle estimate sits 1.3-fold (0.12 log units) above what was measured; the range from low to high includes it.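

Trifluoromethyl, para to a large group, is the only group shown at this place that gives a readable number rather than a limit in this assay. The comparison yields only an at least 1.0-fold lower number from compound 2 to compound 4 (0.03 log units; that floor lies within the scatter) and an at least 1.0-fold lower number from compound 1 to compound 4 (0.03 log units; that floor lies within the scatter), so no shift beyond the scatter can be claimed for trifluoromethyl over methylsulfanyl or hydroxy. The series as shown still sits mostly at one boundary: the limit of > 25000 nM in this assay, at which 3 of the 4 values shown sit.

Going by these compounds, whether an amine or a carboxylic acid at this place would give a number clearly below that limit stays open.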